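A few compounds are considered here, and "the series" means these few. Any claim that something is new, unique, unknown or untested is made for them only; others in the source may bear on it.

Among the compounds with values here, compound 2 `Cc1cccc(N2CCC(C(=O)Nc3ccc4c(c3)NC(=O)CO4)CC2)c1C` gives 28 nM in an assay on HEK293 cells for displacement of a labelled ligand from transient receptor potential cation channel subfamily V member 1 (Homo sapiens) (a lower number here means a stronger inhibitor, a higher number a weaker inhibitor), and holds the lower of the two numbers so far; compound 1 `O=C1COc2ccc(NC(=O)C3CCN(c4cc(F)c(F)c(F)c4)CC3)cc2N1` gives 49 nM, a gap within the scatter. The change to compound 3 `O=C1COc2ccc(NC(=O)C3CCN(c4ccccc4Cl)CC3)cc2N1` is 2-chlorophenyl in place of 2,3-dimethylphenyl on an amine nitrogen in a ring. Within the data shown here, the one step measured at the same place, a 1.8-fold lower number from compound 1 to compound 2 (0.24 log units; within the scatter), lay within the scatter, so swapping the aryl group on this ring nitrogen has so far moved nothing beyond it; a single step is thin ground. For compound 3 the expected step is therefore a 1.3-fold higher number from compound 2 to compound 3 (0.10 log units; within the scatter), none beyond the scatter. Compound 3 is estimated at 35 nM, range 12 nM to 100 nM.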

Compound 3, inhibition constant: 93 nM
Estimate against measurement, compound 3: 2.7-fold (0.42 log units) below; the measured number falls inside the stated range.
By their numbers in this assay, from the lowest: compounds 2, 1 and 3 (each within the scatter of the next, the first and the last beyond it).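

In this assay a change of aryl group on the amine nitrogen of this six-membered ring now reaches beyond the scatter: a 3.3-fold higher number from compound 2 to compound 3 (0.52 log units; beyond the scatter) with 2-chlorophenyl in place of 2,3-dimethylphenyl. Against 3,4,5-trifluorophenyl the same 2-chlorophenyl gives a 1.9-fold higher number from compound 1 to compound 3 (0.28 log units; within the scatter) and stays within the scatter, so only compounds 2 and 3 are separated at this position. Nothing measured here bears on the cause of this step.

Open, going by these compounds, is whether a pyridyl ring or a cyclohexyl group on this nitrogen would hold the number near that of compound 2.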